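Aryl amide swap on a sulfonamide GPR27 agonist scaffold

The source may report more compounds than this note shows. Statements on the series, on what has been measured and on what is new or still open speak of the compounds shown alone.

Measured compounds:
compound 1, `O=C(NS(=O)(=O)c1ccc(NC(=O)c2ccc(Cl)cc2Cl)cc1)c1ccccc1`: > 100000 nM
compound 2, `N#Cc1ccc(C(=O)Nc2ccc(S(=O)(=O)Nc3ccccc3)cc2)c(F)c1`: 229 nM

Of the compounds shown here, two have been measured in a functional assay on HEK293 cells for agonist activity at probable G-protein coupled receptor 27 (Homo sapiens), read by a luciferase reporter and beta-arrestin recruitment, with a stated time of 10 min; a higher number here means that more compound is needed for the effect, a lower number that less compound is needed. For compound 1 the result is only a limit, > 100000 nM, and not a number. For the measured compounds named here, compound 2 is therefore the only compound with a numerical value, 229 nM in this assay. The other result shown is described by the limit of > 100000 nM in this assay, at which 1 of the 2 values shown sits. Compound 3, `COc1cc(Br)ccc1C(=O)Nc1ccc(S(=O)(=O)Nc2ccccc2)cc1`, has not yet been measured. It differs from compound 2 in one place: 4-bromo-2-methoxyphenyl in place of 4-cyano-2-fluorophenyl on a carbonyl carbon. Going by the values given here, because no two measured compounds differ in this single place, there is no measured step to lean on for this change, and the one limit gives no scale for it. The expectation for the step from compound 2 to compound 3 is therefore a modest loss in this assay, with considerable uncertainty, a 2.6-fold higher number from compound 2 to compound 3 (0.42 log units; beyond the scatter). Compound 3 is estimated at 600 nM in this assay, within a range from 150 nM to 3000 nM.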

Compound 3, half-maximal effective concentration: 1020 nM
Compound 3: the middle estimate sits 1.7-fold (0.23 log units) below what was measured; low and high end bracket the measured number.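

The step gives the first measured size for a change at this place, on a carbonyl carbon: in this assay, putting 4-bromo-2-methoxyphenyl in place of 4-cyano-2-fluorophenyl gives a 4.5-fold higher number from compound 2 to compound 3 (0.65 log units; beyond the scatter) and leaves compound 3 with a numerical value. The loss comes with the counts printed for the two groups unchanged, since each holds the same number of heavy atoms, hydrogen-bond donors and hydrogen-bond acceptors and one six-membered aromatic ring of carbon only, so these counts alone do not set the number at this place. None of the measurements shown gives a cause for this step.

Both substituents change at once, so the compounds shown leave open how much of the step belongs to the nitrile or the fluorine leaving and how much to the bromine or the methoxy entering. They also leave open how the number would respond at this place to a ring carrying an amine or a carboxylic acid instead.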